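Swapping Phenyl for Hydroxy on a Toll-like Receptor 8 Agonist

The source may report more compounds than this note shows. Statements on the series, on what has been measured and on what is new or still open speak of the compounds shown alone.

Of the compounds shown here, three built on one shared core have been tested in an assay on HEK293 cells for agonist activity at Toll-like receptor 8 (Homo sapiens), read by reporter gene assay; a lower number here means that less compound is needed, a higher number that more compound is needed for the effect. Compound 1 `CCCCCn1c(N)nc2c(Cl)cccc21` gives "not active" (no number reported), so no number stands for it. Compound 2 `CCCCCn1c(N)nc2c(CC)cccc21` gives 1650 nM, the only numerical result in the set. Compound 3 `CCCCCn1c(N)nc2c(-c3ccccc3)cccc21` likewise gives "not active" (no number reported); it therefore stands without a single number, as does compound 1. Compound 4 `CCCCCn1c(N)nc2c(O)cccc21` is not yet measured and differs from compound 3 by hydroxy in place of phenyl on an aromatic carbon, a hydroxy in place of phenyl on an aromatic carbon. Among the measured compounds shown here, no measured pair shows how large such a change is here, so the direction is open. Because compound 2 gives 1650 nM with a small group, a result of that order seems plausible, though an inactive outcome remains possible. Compound 4 is expected, in this assay, to give 3000 nM, within a range from 500 nM to 20000 nM.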

Compound 4, half-maximal effective concentration: 5010 nM
Compound 4: middle estimate off by 1.7-fold (0.22 log units), on the low side, within the range that was stated.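

In this assay compound 3, with phenyl, gives "not active" (no number reported), while compound 4, with hydroxy, gives a real number, so a measurable response at this aromatic carbon is not limited to ethyl. Replacing ethyl with hydroxy gives a 3.0-fold higher number from compound 2 to compound 4 (0.48 log units; beyond the scatter) and so weakens the response without abolishing it.

Going by these compounds, whether an amine or a methoxy group on this carbon would fall nearer hydroxy or phenyl stays open, as does how a longer chain would compare with ethyl. Nothing measured here explains these differences.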